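A few compounds are considered here, and "the series" means these few. Any claim that something is new, unique, unknown or untested is made for them only; others in the source may bear on it.

Compound 2 `COc1ccc(OCc2cccnc2)c(C=O)c1` stands, in a functional assay on cells (Erythrocyte, Homo sapiens), with a stated time of 2 h, tested at 2 mM (on this read-out higher numbers stand for a stronger effect at the one concentration tested and lower numbers for a weaker effect), at 90.5%, the higher of the two numbers in hand, with compound 1 `COc1ccc(OCc2ccccn2)c(C=O)c1` nearest at 90.3%. Among the compounds with values here, the one measured step, a number 0.2 percentage points higher from compound 1 to compound 2 (within the scatter), lies within the scatter, so the two are not separated on this read-out. Compound 3 `COc1ccc(OCc2ccncc2)c(C=O)c1` is not yet measured; it differs from compound 2 by pyridin-4-yl in place of pyridin-3-yl on a saturated chain carbon bound to an oxygen on an aromatic ring. The step from compound 1 to compound 2 is the only one that bears on this change, since it also moves the ring nitrogen within the pyridinyl on the same saturated chain carbon, and it was flat. The step of a number 1.5 percentage points lower from compound 2 to compound 3 (within the scatter) is therefore expected to be none beyond the scatter, with the read-out already near its upper end. Compound 3 is estimated at 89%, within a range from 78% to 97%.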

Compound 3, a percentage reported as inhibition, at one concentration (the size of the read-out at that concentration, not a potency): 85.9%
Beside the measured number, compound 3's estimate is 3.1 percentage points above it, and the stated range covers the measured number.
By their numbers in this assay, from the lowest: compounds 3, 1 and 2 (each within the scatter of the next).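

With pyridin-4-yl, the set now holds three pyridinyl isomers on the saturated chain carbon bound to an oxygen on an aromatic ring, and in this assay the two new steps are a number 4.6 percentage points lower from compound 2 to compound 3 (within the scatter) and a number 4.4 percentage points lower from compound 1 to compound 3 (within the scatter). Moving the ring nitrogen around the pyridinyl therefore sets no order among the three compounds on this read-out, which extends the flat first comparison to all three isomers. No available data address a cause for these numbers.

Still open, as far as these compounds go, is whether phenyl, an aminomethyl-substituted phenyl or a carboxylic acid in place of the pyridinyl, or a longer chain carrying it, would move the read-out beyond the scatter. From the compounds shown here alone, with one concentration per compound, whether the three isomers would differ in effect at other concentrations also remains open.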